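This account rests on a few compounds, and the source may have more. Where it says the series, first, only, none or still open, it means among the compounds named here.

The measured compounds, with their antiproliferative read-out:

compound 1, `CCC(=O)Nc1nc(CN=C=S)cs1`: 6800 nM
compound 2, `CC(C)C(=O)Nc1nc(CN=C=S)cs1`: 8200 nM
compound 3, `CCC(=O)Nc1nc(CN=C=S)c[se]1`: 3500 nM

All three were tested in a functional assay on L1210 cells (Mus musculus) for antiproliferative activity; a lower number here means a stronger inhibitor, a higher number a weaker inhibitor. Compound 1 and compound 2 share a core and differ by one change, (methyl in place of hydrogen on a saturated chain carbon bound to a carbonyl carbon and a saturated chain carbon). That change gave a 1.2-fold higher number from compound 1 to compound 2 (0.08 log units; within the scatter), so the two numbers cannot be told apart. Compound 3 carries a different core; how its core differs from that of compound 1 is not broken down here. In this assay compound 3 gives 3500 nM, a number within the scatter of compound 1 and beyond the scatter of compound 2, so compound 3 gives a lower number than compound 2, while compound 3 and compound 1 cannot be ordered.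

Compound 4, `CC(C)C(=O)Nc1nc(CN=C=S)c[se]1`, has not yet been measured. Within the data shown here, it stands to compound 3 as compound 2 stands to compound 1: the change is methyl in place of hydrogen on a saturated chain carbon bound to a carbonyl carbon and a saturated chain carbon, the same change as the one from compound 1 to compound 2, made at the same place. Because that change gave a 1.2-fold higher number from compound 1 to compound 2 (0.08 log units; within the scatter), compound 4 is expected to stay close to compound 3, with an expected step of a 1.2-fold higher number from compound 3 to compound 4 (0.08 log units; within the scatter). This rests on a single measured pair, so the range is kept broad. For compound 4 the estimate in this assay is 4200 nM, expected to fall between 2400 nM and 7500 nM.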

Compound 4, half-maximal inhibitory concentration: 28000 nM
Compound 4: the middle estimate sits 6.7-fold (0.82 log units) below what was measured; measured number above the stated range.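

In this assay, putting methyl in place of hydrogen on the saturated chain carbon bound to a carbonyl carbon and a saturated chain carbon, which turns propanoyl into isopropylcarbonyl, gave an 8.0-fold higher number from compound 3 to compound 4 (0.90 log units; beyond the scatter) on the core of compound 3. Among these compounds, in this series, then, the size of this change's effect did not carry from one core to the other, and the step measured on the core of compound 1 proved a poor guide to the step on the core of compound 3: the same change on two cores in this assay, a 1.2-fold higher number (0.08 log units; within the scatter) from compound 1 to compound 2 and an 8.0-fold higher number (0.90 log units; beyond the scatter) from compound 3 to compound 4, 6.6-fold (0.82 log units) apart, beyond the scatter of two such steps This does not show which difference between the cores goes with the gap, nor does it set a general rule for moving changes between these cores, as the comparison rests on only one pair of compounds on each core.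

The compounds shown leave open whether the gap between the cores would persist with a longer chain, such as butanoyl, or with a ring-bearing group such as cyclopropyl in place of the isopropyl. They also leave open whether a polar group such as an amine or a carboxylic acid on that chain would separate the two cores in the same way.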